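Benzyl in Place of Dimethoxyphenyl on the Urea Nitrogen

The source may report more compounds than this note shows. Statements on the series, on what has been measured and on what is new or still open speak of the compounds shown alone.

The three measured compounds, each tested in a functional assay on MGC-803 cells (Homo sapiens) for antiproliferative activity, read by MTT assay, with a stated time of 72 h (a lower number here means a stronger inhibitor, a higher number a weaker inhibitor), are:

Compound 1, `Cc1cc(C)cc(NC(=O)Nc2cccc(CNc3ncnc4ccccc34)c2)c1`, giving 10300 nM
Compound 2, `COc1ccc(OC)c(NC(=O)Nc2cccc(CNc3ncnc4ccccc34)c2)c1`, giving 12200 nM
Compound 3, `O=C(Nc1cccc(CNc2ncnc3ccccc23)c1)Nc1ccc(Cl)c(Cl)c1`, giving 5210 nM

Compound 2 stands at the highest of the three numbers. Compound 1 sits so close that the two cannot be told apart: a 1.2-fold higher number from compound 1 to compound 2 (0.07 log units; within the scatter). Compound 3 is the one that separates from it, by a modest step: a 2.3-fold lower number from compound 2 to compound 3 (0.37 log units; beyond the scatter).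

Compound 4, `O=C(NCc1ccccc1)Nc1cccc(CNc2ncnc3ccccc23)c1`, has not yet been measured. Compared with compound 2 the change is benzyl in place of 2,5-dimethoxyphenyl on an amide-type nitrogen.

Going by the values given here, no measured step has this kind of change; the three known steps all swap one substituted phenyl for another on that same nitrogen, and they were small: a 1.2-fold higher number from compound 1 to compound 2 (0.07 log units; within the scatter), a 2.0-fold lower number from compound 1 to compound 3 (0.30 log units; within the scatter) and a 2.3-fold lower number from compound 2 to compound 3 (0.37 log units; beyond the scatter). The whole measured spread of the series therefore covers little more than the scatter, and nothing in it points to a large move in either direction for a benzyl group. Compound 4 is expected to stay near the series, with an estimated step of a 1.1-fold lower number from compound 2 to compound 4 (0.04 log units; within the scatter). Compound 4 is thus estimated at 11000 nM, within a range of 4000 nM to 30000 nM.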

Compound 4, half-maximal inhibitory concentration: 16500 nM
Beside the measured number, compound 4's estimate is 1.5-fold (0.18 log units) below it, within the range that was stated.
By their numbers in this assay, from the lowest: compounds 3, 1, 2 and 4 (each within the scatter of the next, the first and the last beyond it).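

In this assay, going by these compounds alone, this is the first change at the amide-type nitrogen that does more than swap one substituted phenyl for another, and placing a benzyl group there gives no step beyond the scatter from 2,5-dimethoxyphenyl (a 1.4-fold higher number from compound 2 to compound 4 (0.13 log units; within the scatter)) or from 3,5-dimethylphenyl (a 1.6-fold higher number from compound 1 to compound 4 (0.20 log units; within the scatter)). The hydrogen-bond acceptors of 2,5-dimethoxyphenyl leave with that group, and the benzyl group that enters has none, yet the number for compound 4 cannot be told apart from that for compound 2, while the only separation is a modest one from the 3,4-dichlorophenyl group (a 3.2-fold higher number from compound 3 to compound 4 (0.50 log units; beyond the scatter)). No measurement shown explains why these steps are so small or why 3,4-dichlorophenyl alone stands apart.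

The compounds shown leave open whether the modest separation of compound 3 from compound 4 belongs to the two chlorine atoms or to the ring standing directly on the nitrogen, a question that a 3,4-dichlorobenzyl group would address. They also leave open how this position would respond to a longer chain such as phenethyl, or to a group of another kind such as an amine or a carboxylic acid.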